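Swapping One Aromatic Ring in a Tight Series

A few compounds are considered here, and "the series" means these few. Any claim that something is new, unique, unknown or untested is made for them only; others in the source may bear on it.

In a functional assay on CNE-2 cells (Homo sapiens) for antiproliferative activity, read by sulforhodamine B assay, with a stated time of 48 h (on this read-out higher numbers stand for weaker inhibition and lower numbers for stronger inhibition), compound 1 `COc1ccc(C=C(C(=O)/C=C/c2cccc(OC)c2OC)C(=O)/C=C/c2cccc(OC)c2OC)cc1OC` gives 280 nM. Within the data shown here, this puts it in a tight group, since compound 2 `COc1cccc(/C=C/C(=O)C(=Cc2cc(OC)c(OC)c(OC)c2)C(=O)/C=C/c2cccc(OC)c2OC)c1OC` gives 400 nM and compound 3 `COc1cccc(/C=C/C(=O)C(=Cc2ccc(O)c(F)c2)C(=O)/C=C/c2cccc(OC)c2OC)c1OC` gives 260 nM, with no pair separated beyond the scatter. Compound 4 `COc1cc(C=C(C(=O)/C=C/c2cccc(OC)c2OC)C(=O)/C=C/c2cccc(OC)c2OC)cc(OC)c1O` has not yet been measured, and its change from compound 1 is 4-hydroxy-3,5-dimethoxyphenyl in place of 3,4-dimethoxyphenyl on a double-bonded chain carbon bound to a double-bonded chain carbon. Two measured steps alter this same aromatic group: methoxy in place of hydrogen gave a 1.4-fold higher number from compound 1 to compound 2 (0.15 log units; within the scatter), and 3-fluoro-4-hydroxyphenyl in place of 3,4-dimethoxyphenyl gave a 1.1-fold lower number from compound 1 to compound 3 (0.03 log units; within the scatter). Neither left the scatter, so no real shift is expected here. The expected step is a 1.1-fold higher number from compound 1 to compound 4 (0.03 log units; within the scatter). For compound 4 the estimated value is 300 nM, with an expected range of 130 nM to 650 nM.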

Compound 4, half-maximal inhibitory concentration: 300 nM
Beside the measured number, compound 4's estimate shows no gap at the digits printed; low and high end bracket the measured number.
By their numbers in this assay, from the lowest: compounds 3, 1, 4 and 2 (each within the scatter of the next).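

In this assay, among these compounds, hydrogen in place of methyl on an oxygen on the aromatic ring gives a 1.3-fold lower number from compound 2 to compound 4 (0.12 log units; within the scatter) and offers a direct comparison that no earlier pair provided. The other two new comparisons give a 1.1-fold higher number from compound 1 to compound 4 (0.03 log units; within the scatter) and a 1.2-fold higher number from compound 3 to compound 4 (0.06 log units; within the scatter) and show that the four forms of this aromatic group, with and without a hydrogen-bond donor, stay within the scatter. No measurement shown explains this flat result.

On these data alone, whether an amine or a carboxylic acid on this ring would produce a real shift remains open. So does the effect of changing the other two aromatic rings, which are identical in all four compounds.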